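A few compounds are considered here, and "the series" means these few. Any claim that something is new, unique, unknown or untested is made for them only; others in the source may bear on it.

Of the compounds shown here, two from this set have been measured in an assay on CHO cells for displacement of a labelled ligand from prostaglandin D2 receptor 2 (Homo sapiens); on this read-out higher numbers stand for weaker inhibition and lower numbers for stronger inhibition. Compound 1 `CC1(c2cc(Cl)ccc2OCC(=O)O)CCCCC1` gives 90 nM in this assay. Compound 2 `O=C(O)COc1ccc(Br)cc1C1CCCCC1` gives 83 nM in this assay, the lowest of the two numbers, but its gap to compound 1 lies within the scatter, so the two cannot be told apart on these data. Compound 3 `Cc1ccc(OCC(=O)O)c(C2CCCCC2)c1` has not been measured yet. It differs from compound 2 in one place: methyl in place of bromo on an aromatic carbon. Among the measured compounds shown here, no pair of measured compounds differs in this way, so nothing measured here shows what such a swap does, and the two numbers at hand are indistinguishable from each other. For the measured compounds named here, with no guidance from measured steps, the change from compound 2 is expected to be modest at most. The expected step of a 1.8-fold higher number from compound 2 to compound 3 (0.26 log units; within the scatter) is meant to stay close to the scatter. Compound 3 is estimated at 150 nM in this assay, with a range from 50 nM to 500 nM.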

Compound 3, inhibition constant: 353 nM
Compound 3: the middle estimate sits 2.4-fold (0.37 log units) below what was measured, and the stated range covers the measured number.
By their numbers in this assay, from the lowest: compounds 2 and 1 (each within the scatter of the next); then compound 3.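

Replacing bromo with methyl on the aromatic carbon para to a carboxymethoxy group gives the first difference in this set that clearly exceeds the scatter: in this assay, the swap produces a 4.3-fold higher number from compound 2 to compound 3 (0.63 log units; beyond the scatter), meaning weaker inhibition. This position is therefore sensitive to which group it carries, even though bromo and methyl each count as one heavy atom and neither has hydrogen-bond donors or acceptors. No measured evidence here accounts for the difference between the two groups.

The compounds shown leave open how a nitrile, a methoxy or a trifluoromethyl group would behave on this same carbon. They also leave open whether methyl in place of a halogen would give a similar step on the core of compound 1.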